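The source may report more compounds than this note shows. Statements on the series, on what has been measured and on what is new or still open speak of the compounds shown alone.

Measured compounds:
- compound 1, `CN1CCN(c2ccc(Nc3ncc4nc(Nc5ccccc5)n([C@H]5CCNC5)c4n3)cc2)CC1`: "not determined" (no result reported)
- compound 2, `CN1CCN(c2ccc(Nc3ncc4nc(Nc5ccc(F)cc5)n([C@H]5CCN(C(=O)CO)C5)c4n3)cc2)CC1`: "not determined" (no result reported)
- compound 3, `CN1CCN(c2ccc(Nc3ncc4nc(Nc5ccccc5)n([C@@H]5CCN(S(=O)(=O)C6CC6)C5)c4n3)cc2)CC1`: > 10000 nM
- compound 4, `CN1CCN(c2ccc(Nc3ncc4nc(Nc5ccc(F)cc5)n(-c5cccc(NC(=O)CO)c5)c4n3)cc2)CC1`: still to be measured

All four share one core and differ in the group carried on the aromatic nitrogen. In a functional assay on A-431 cells (Homo sapiens) for antiproliferative activity, read by MTT assay, with a stated time of 72 h (on this read-out higher numbers stand for weaker inhibition and lower numbers for stronger inhibition), compound 3 reaches only a limit, > 10000 nM, and no number is given. Compound 1 has no result at all in this assay. Compound 2 likewise has no number of its own in this assay, so it cannot be placed against either neighbour: of the three entries shown, one is a limit and one is empty, which is summed up by the limit of > 10000 nM in this assay, at which 1 of the 3 values shown sits.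

The move from compound 2 to compound 4 is 3-(((hydroxymethyl)carbonyl)amino)phenyl in place of 1-((hydroxymethyl)carbonyl)pyrrolidin-3-yl on an aromatic nitrogen. Within the data shown here, no pair of measured compounds differs in one place, so no measured step exists on which the size or direction of this change could rest. With only a limit in hand, the expectation for compound 4 in this assay is a weak result, without a shift beyond the usual scatter being claimed in either direction. Compound 4 is therefore expected to give about 8000 nM, in a range from 1500 nM to 30000 nM.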

Compound 4, half-maximal inhibitory concentration: 1670 nM
Estimate against measurement, compound 4: 4.8-fold (0.68 log units) above; low and high end bracket the measured number.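

No new step can be read for compound 4, because compound 2 has no number of its own in this assay and compound 3 gives only a limit: the limit of > 10000 nM in this assay, at which 1 of the 4 values shown sits.

The compounds shown leave open how far exchanging 1-((hydroxymethyl)carbonyl)pyrrolidin-3-yl for 3-(((hydroxymethyl)carbonyl)amino)phenyl on the shared core changes inhibition, and in which direction.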